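This account rests on a few compounds, and the source may have more. Where it says the series, first, only, none or still open, it means among the compounds named here.

Compound 1 `O=C1NC(=S)S/C1=C\C1=Cc2ccccc2OC1` is the starting point of this account. In a functional assay on MOLT-4 cells (Homo sapiens) for antiproliferative activity, read by MTT assay, with a stated time of 72 h (on this read-out lower numbers stand for stronger inhibition and higher numbers for weaker inhibition), compound 1 gives 52000 nM. Compound 2 `CN1C(=N)NC(=O)/C1=C/C1=Cc2ccccc2OC1`, in which the ring bearing the exocyclic double bond carries a different set of heteroatoms, gives 72000 nM in this assay, a figure that sits within the scatter of the value for compound 1, so the two cannot be placed in order. Compound 3 `O=C(O)CN1C(=O)/C(=C/C2=Cc3ccccc3OC2)SC1=S` returns only a limit in this assay, > 100000 nM, and the step from compound 1 to compound 3 is an at least 1.9-fold higher number from compound 1 to compound 3 (0.28 log units; that floor lies within the scatter), which rests on the limit of > 100000 nM in this assay, at which 1 of the 3 values shown sits, rather than on a measured number.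

Compound 4 `O=C1NC(=S)S/C1=C\C1=Cc2cc(Br)ccc2OC1` differs from compound 1 by bromo in place of hydrogen on an aromatic carbon. Going by the values given here, none of the measured steps touches the aromatic ring, so no measured step bears directly on this change, and on that basis nothing beyond the scatter is expected in this assay. Compound 4 is therefore estimated at 40000 nM, with a range from 15000 nM to 100000 nM, and the expected step from compound 1 to compound 4 is a 1.3-fold lower number from compound 1 to compound 4 (0.11 log units; within the scatter).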

Compound 4, half-maximal inhibitory concentration: 38200 nM
Estimate against measurement, compound 4: 1.0-fold (0.02 log units) above, and the stated range covers the measured number.
By their numbers in this assay, from the lowest: compounds 4, 1 and 2 (each within the scatter of the next). At a limit, above all of these: compound 3.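

Bromo in place of hydrogen on the aromatic carbon gives, in this assay, a 1.4-fold lower number from compound 1 to compound 4 (0.13 log units; within the scatter), so this carbon of the shared core takes a bromo with no effect that can be told from the scatter. The earlier compounds shown here differ only in the ring bearing the exocyclic double bond, which makes this the first reading from the aromatic ring, and compound 1 and compound 4 cannot be placed in order. Nothing measured here accounts for this small step.

As far as these compounds go, whether another group on this same carbon, such as an amine, a carboxylic acid or a methoxy group, would shift the number beyond the scatter remains open. So does the question of whether bromo on another aromatic carbon of the core would read the same way.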